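Changing the side chain on a shared core

This account rests on a few compounds, and the source may have more. Where it says the series, first, only, none or still open, it means among the compounds named here.

Measured in a functional assay on SH-SY5Y cells (Homo sapiens) for cytotoxicity, read by MTT assay, with a stated time of 72 h; a higher number here means a weaker inhibitor, a lower number a stronger inhibitor:
- compound 1 `O=C1c2c[n+]([O-])c3ccccc3c2C(=O)c2c1c1ccccc1n2Cc1cn(CC(O)CO)nn1`: > 1000 nM (a limit)
- compound 2 `O=C1c2c[n+]([O-])c3ccccc3c2C(=O)c2c1c1ccccc1n2Cc1cn(C[C@@H](O)CO)nn1`: > 500 nM (a limit)

Neither compound has an exact number, so compound 2 can be placed only by its limit of > 500 nM. Within the data shown here, the one measured step is a step that the two limits leave unreadable from compound 1 to compound 2. That step concerns the fact that one of compounds 1 and 2 is drawn with a defined configuration and the other without, at the place where they differ and leaves the side chain untouched, so it offers no size to carry forward.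

Compound 3 `CN1CCN(CCCCCn2c3c(c4ccccc42)C(=O)c2c[n+]([O-])c4ccccc4c2C3=O)CC1` keeps the shared core, but its side chain changes on a saturated chain carbon bound to an aromatic nitrogen: 4-(4-methylpiperazin-1-yl)butyl in place of 1-(2,3-dihydroxypropyl)-1H-1,2,3-triazol-4-yl on a saturated chain carbon bound to an aromatic nitrogen. Among the measured compounds shown here, no measured step covers this kind of change, so no direction can be expected with confidence in this assay. The estimated step, which is very uncertain, is a step that the limit leaves unreadable from compound 2 to compound 3. Compound 3 is expected to give about 1500 nM, with an estimated range of 300 nM to 8000 nM.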

Compound 3, half-maximal inhibitory concentration: 830 nM
For compound 3 the middle estimate is 1.8-fold (0.26 log units) above the measured one, and the stated range covers the measured number.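

Among these compounds, at the place on a saturated chain carbon bound to an aromatic nitrogen, the 4-(4-methylpiperazin-1-yl)butyl group of compound 3 gives the first exact number in this assay, 830 nM. The one readable step for this change is an at least 1.2-fold lower number from compound 1 to compound 3 (0.08 log units; that floor lies within the scatter), so the change is not shown to move the number beyond ordinary repeat variation. The step that starts from compound 2 cannot be read, because compound 2 has only a limit: the limit of > 500 nM in this assay, at which 1 of the 3 values shown sits.

Going by these compounds, whether this swap changes the result at all therefore remains open, and so does the separate share of the triazole ring, the piperazine ring and the chain. Also open, on these data alone, is how a simple primary amine or a carboxylic acid at this same place would read in this assay.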